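Metabolic stability notes: replacing the acid-bearing ring in compound 1

This account rests on a few compounds, and the source may have more. Where it says the series, first, only, none or still open, it means among the compounds named here.

Compound 1 `C[C@]1(C(=O)N2CC[C@](c3ccc(C(F)(C(F)(F)F)C(F)(F)F)cc3)(S(=O)(=O)c3ccc(F)cc3)C2)CC[C@H](C(=O)O)CC1` gives 95% in an ADME assay on microsomes from liver (Mus musculus) for metabolic stability, with a stated time of 10 min; a higher number here means that more of the compound is left, a lower number that less of the compound is left. Compound 2 `CO[C@]1(C(=O)N2CC[C@](c3ccc(C(F)(C(F)(F)F)C(F)(F)F)cc3)(S(=O)(=O)c3ccc(F)cc3)C2)CC[C@H](C(=O)O)CC1` gives 95%, and the step of no change at the digits printed from compound 1 to compound 2 (within the scatter) shows no change within the scatter. Compound 3 `O=C(O)C1CCC(O)(C(=O)N2CC[C@](c3ccc(C(F)(C(F)(F)F)C(F)(F)F)cc3)(S(=O)(=O)c3ccc(F)cc3)C2)CC1` gives 99%; 98% (2 entries); its repeated entries the several entries of compound 3 in this assay, 99%; 98% (2 entries) show how close repeats sit. Compound 1 thus stands level with compound 2, and all three measured compounds remain near the top of the read-out.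

Compound 4 `O=C(N1CC[C@](c2ccc(C(F)(C(F)(F)F)C(F)(F)F)cc2)(S(=O)(=O)c2ccc(F)cc2)C1)C1(O)CCS(=O)(=O)CC1` is unmeasured. Its change from compound 1 is 4-hydroxy-1,1-dioxothian-4-yl in place of 4-carboxy-1-methylcyclohexyl on a carbonyl carbon. For the measured compounds named here, no measured step covers this change; the only measured step, from compound 1 to compound 2, was flat. With every measured compound high, the step of a number 2 percentage points lower from compound 1 to compound 4 (within the scatter) is expected to stay within the scatter. The estimate for compound 4 is 93%, with a range from 80% to 99%.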

Compound 4, percent of the compound remaining: 90%
Beside the measured number, compound 4's estimate is 3 percentage points above it; low and high end bracket the measured number.
By their numbers in this assay, from the lowest: compounds 4, 1 and 2 (each within the scatter of the next).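

Here the whole group on the carbonyl carbon changes, not just one substituent on the ring, and 4-hydroxy-1,1-dioxothian-4-yl in place of the carboxy-bearing cyclohexyl groups gives, in this assay, a number 5 percentage points lower from compound 1 to compound 4 (within the scatter) and a number 5 percentage points lower from compound 2 to compound 4 (within the scatter). A carboxy group and a carbon-only ring are therefore not needed at this position for a reading near the top of the scale. Repeats show how close entries sit: the several entries of compound 3 in this assay, 99%; 98% (2 entries)

As far as these compounds go, whether any group at this position can lower the number stays open. An amine or a longer chain on the carbonyl carbon would test that.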